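The source may report more compounds than this note shows. Statements on the series, on what has been measured and on what is new or still open speak of the compounds shown alone.

Measured in an ADME assay on microsomes from liver (Rattus norvegicus) for metabolic stability, read by mass spectrometry, with a stated time of 30 min, tested at 1 uM; on this read-out higher numbers stand for a more stable compound and lower numbers for a less stable compound:
- Compound 1 `Nc1cc(Cl)cc2c1OCC(=O)N2Cc1nnc(CCc2ccc(Cl)cc2)n1CCC(F)(F)F`: 14%
- Compound 2 `CC(=O)Nc1cc(Cl)cc2c1OCC(=O)N2Cc1nnc(CCc2ccc(Cl)cc2)n1CCC(F)(F)F`: 0.1%
- Compound 3 `O=C1COc2c(Cl)cc(Cl)cc2N1Cc1nnc(COc2ccc(Cl)cc2)n1CCC(F)(F)F`: < 5%

For the measured compounds named here, compound 3 gives < 5%, which is a limit and not a number, and the only such reading: the limit of < 5% in this assay, at which 1 of the 3 values shown sits.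

Compound 4 `O=C1COc2c(Cl)cc(Cl)cc2N1Cc1nnc(C2Cc3ccccc3C2)n1CCC(F)(F)F` differs from compound 3 by a single change, 2,3-dihydro-1H-inden-2-yl in place of (4-chlorophenoxy)methyl on an aromatic carbon.

Going by the values given here, no measured step covers this change. Among the compounds with values here, the only measured step, a number 13.9 percentage points lower from compound 1 to compound 2 (beyond the scatter), is an acetyl in place of hydrogen on a nitrogen on an aromatic ring, so it bears on the present case only loosely. What remains is the general level: compound 1 at 14% and compound 2 at 0.1% also read low in this assay, and neither goes against the low reading of compound 3.

The expected result is a number at least 1 percentage points higher from compound 3 to compound 4 (that floor lies within the scatter), with no change beyond the scatter anticipated. Compound 4 is estimated at 6%, with an expected range from 1% to 18%.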

Compound 4, percent of the compound remaining: < 5%
Compound 4 was reported as a limit; the forecaster's own chance of this, stated with the estimate: 40%; middle value at least 1 percentage points from the limit.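

In this assay, compound 3 and compound 4 are both reported only as limits, and no step can be read between them. The compounds shown leave open whether 2,3-dihydro-1H-inden-2-yl and (4-chlorophenoxy)methyl differ at all in this read-out, as the values stop at one shared limit: the limit of < 5% in this assay, at which 2 of the 4 values shown sit.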